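Benzyl for ethyl on the triazole of compound 1

The source may hold more compounds than are shown below. What is called first, only, known or untested is meant among the compounds shown, and "the series" means these compounds.

Among the compounds with values here, compound 1 `CCn1cc(COc2cc(O)c3c(c2)O[C@H](c2ccc(OC)c(O)c2)CC3=O)nn1` is the weaker of the two measured members in a functional assay on RAW264.7 cells (Mus musculus) for inhibition, read by Griess assay, with stated times of 2 h and 24 h (a higher number here means a weaker inhibitor, a lower number a stronger inhibitor), where compound 1 gives 15000 nM. The other measured member is compound 2 `COc1ccc([C@@H]2C/C(=N\O)c3c(O)cc(OCc4cn(-c5ccccc5)nn4)cc3O2)cc1O`; in this assay compound 2 gives 6130 nM, a lower number than that of compound 1 and a gap that lies beyond the usual scatter. Within the data shown here, no pair of measured compounds differs in a single place, so no single-change step is known yet.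

The next compound is compound 3 `COc1ccc([C@@H]2CC(=O)c3c(O)cc(OCc4cn(Cc5ccccc5)nn4)cc3O2)cc1O`. Against compound 1 the change is phenyl in place of methyl on a saturated chain carbon bound to an aromatic nitrogen. Nothing measured isolates this change, so the expectation rests on the two values only. Among the measured compounds shown here, the series so far spans a narrow range, and a small shift to a lower number is thought plausible for compound 3, though a result within the scatter of compound 1 cannot be excluded. The step expected from a 1.7-fold lower number from compound 1 to compound 3 (0.22 log units; within the scatter) is a modest one toward stronger inhibition. In this assay compound 3 is estimated at 9000 nM, expected to fall between 3500 nM and 25000 nM.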

Compound 3, half-maximal inhibitory concentration: 11000 nM
Compound 3: the middle estimate sits 1.2-fold (0.09 log units) below what was measured, and the stated range covers the measured number.
By their numbers in this assay, from the lowest: compounds 2, 3 and 1 (each within the scatter of the next, the first and the last beyond it).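

In this assay, within the data shown here, this is the first step that isolates one place: the exchange of methyl for phenyl on a saturated chain carbon bound to an aromatic nitrogen, which reads as ethyl to benzyl when cut one bond further out, gives a 1.4-fold lower number from compound 1 to compound 3 (0.13 log units; within the scatter) as its result. Ethyl and benzyl therefore cannot be told apart at this position in this read-out, and the added six-membered aromatic ring of carbon only leaves the number within the scatter on the shared core. No measurement at hand bears on the reason for this result.

Among these compounds, compound 2 differs from compound 1 and from compound 3 in more than one place, so no step to it can be read, and the lower number of compound 2 cannot be assigned to any single part of its structure. On these data alone, whether a longer chain, an amine or a carboxylic acid in place of the phenyl on that saturated chain carbon would move the number beyond the scatter remains open.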